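Swapping a furan for a cyanophenyl on the shared core

This account rests on a few compounds, and the source may have more. Where it says the series, first, only, none or still open, it means among the compounds named here.

Compound 1 `NC(=O)[C@@H]1[C@H](Nc2nc(Nc3cccc(C(=O)N4CCCC4)c3)ncc2-c2ccoc2)[C@H]2C=C[C@@H]1C2` is the most potent of the three measured compounds in a functional assay on THP-1 cells (Homo sapiens) for inhibition, read by ELISA, with stated times of 1 h and 18 h (a lower number here means a stronger inhibitor, a higher number a weaker inhibitor), giving 40 nM. Its nearest neighbour is compound 3 `NC(=O)[C@@H]1[C@H](Nc2nc(Nc3cccc(C(=O)N4CCCC4)c3)ncc2-c2cncc(F)c2)[C@H]2C=C[C@@H]1C2`, which carries a 5-fluoropyridin-3-yl in place of the furan-3-yl and gives 170 nM; compound 2 `NC(=O)[C@@H]1[C@H](Nc2nc(Nc3cccc(C(=O)N4CCCC4)c3)ncc2-c2cccc(F)c2)[C@H]2C=C[C@@H]1C2`, with a 3-fluorophenyl on the same aromatic carbon, lies furthest away and gives 870 nM. Both replacements weaken inhibition: a 22-fold higher number from compound 1 to compound 2 (1.34 log units; beyond the scatter) and a 4.3-fold higher number from compound 1 to compound 3 (0.63 log units; beyond the scatter). Between the two six-membered rings, a 5.1-fold lower number from compound 2 to compound 3 (0.71 log units; beyond the scatter).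

Compound 4 `N#Cc1cccc(-c2cnc(Nc3cccc(C(=O)N4CCCC4)c3)nc2N[C@H]2[C@@H](C(N)=O)[C@@H]3C=C[C@H]2C3)c1` has not yet been measured. It differs from compound 1 by 3-cyanophenyl in place of furan-3-yl on an aromatic carbon. Like compound 2 it carries a six-membered aromatic ring of carbon only, and that step cost a great deal; yet like compound 3 it brings a hydrogen-bond acceptor into the entering group, and compound 3 lost far less than compound 2. The two measured steps from compound 1 therefore bear on it in opposite degree, and the expected result is an increase in the number beyond the scatter of intermediate size, namely a 7.5-fold higher number from compound 1 to compound 4 (0.88 log units; beyond the scatter). Compound 4 is accordingly estimated at 300 nM, with a likely range from 100 nM to 900 nM.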

Compound 4, half-maximal inhibitory concentration: 280 nM
The estimate for compound 4 lay 1.1-fold (0.03 log units) above the measured number; low and high end bracket the measured number.
By their numbers in this assay, from the lowest: compound 1; then compounds 3 and 4 (each within the scatter of the next); then compound 2.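

In this assay, a nitrile in place of the fluoro on the phenyl ring recovers part of what the 3-fluorophenyl group lost (a 3.1-fold lower number from compound 2 to compound 4 (0.49 log units; beyond the scatter)), so the large loss seen with compound 2 does not follow from a six-membered aromatic ring of carbon only. Even so, 3-cyanophenyl does not match furan-3-yl at this aromatic carbon (a 7.0-fold higher number from compound 1 to compound 4 (0.85 log units; beyond the scatter)), and it cannot be told apart from 5-fluoropyridin-3-yl (a 1.6-fold higher number from compound 3 to compound 4 (0.22 log units; within the scatter)), which means that the ring nitrogen of compound 3 and the nitrile of compound 4 leave the number in the same range, and all three six-membered rings shown stay weaker than the furan of compound 1. Nothing available explains these differences in the numbers.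

The compounds shown leave open whether the advantage of compound 1 belongs to five-membered rings in general, which thiophen-3-yl or pyrazol-4-yl would test, or to furan-3-yl alone. They also leave open how unsubstituted phenyl, 4-cyanophenyl or a methoxy group in place of the nitrile would compare with compound 4.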